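The compounds below may be only part of what the source reports. "The series", "measured", "known", "first", "only" and "open" are said of these compounds alone.

Of the compounds shown here, two have been measured in a functional assay on NCI-H1975 cells (Homo sapiens) for antiproliferative activity, read by MTT assay, with a stated time of 72 h; on this read-out higher numbers stand for weaker inhibition and lower numbers for stronger inhibition. In this assay compound 1, whose structure is `COc1cc2ncnc(Nc3cccc(Cl)c3)c2cc1OCCCCC(=O)Nc1ccc(S(N)(=O)=O)cc1`, gives 33200 nM. Compound 2, whose structure is `NS(=O)(=O)c1ccc(NC(=S)Nc2ccc3ncnc(Nc4ccc(F)c(Cl)c4)c3c2)cc1`, gives 15800 nM in this assay. Of these two numbers compound 2 has the lower one, and its distance from compound 1 lies beyond the usual scatter, so compound 2 is the stronger of the two measured inhibitors.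

The next compound, compound 3, whose structure is `NS(=O)(=O)c1ccc(NC(=S)Nc2ccc3ncnc(Nc4ccc(C(F)(F)F)cc4)c3c2)cc1`, differs from compound 2 in one place: 4-(trifluoromethyl)phenyl in place of 3-chloro-4-fluorophenyl on a nitrogen on an aromatic ring. Both groups sit on the same nitrogen, and neither carries a hydrogen-bond donor or acceptor. For the measured compounds named here, no measured pair in this set shows the effect of this exchange, so there is no step to lean on, and a change of this kind may well fall within the scatter or shift the number a small amount either way. The step that the estimate means is a 1.6-fold higher number from compound 2 to compound 3 (0.20 log units; within the scatter), expected to lean toward a slightly higher number. On that basis compound 3 is expected to give about 25000 nM in this assay, within a range from 8000 nM to 80000 nM.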

Compound 3, half-maximal inhibitory concentration: 17100 nM
The estimate for compound 3 lay 1.5-fold (0.16 log units) above the measured number, within the range that was stated.
By their numbers in this assay, from the lowest: compounds 2, 3 and 1 (each within the scatter of the next, the first and the last beyond it).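

In this assay, for the compounds shown here, putting 4-(trifluoromethyl)phenyl in place of 3-chloro-4-fluorophenyl on a nitrogen on an aromatic ring gives a 1.1-fold higher number from compound 2 to compound 3 (0.03 log units; within the scatter), and this is the first pair that differs in one place only. So at this place, a ring with chlorine and fluorine and a ring with a trifluoromethyl group cannot be told apart by this read-out, even though the group size goes from 8 to 10 heavy atoms and neither group has a hydrogen-bond donor or acceptor. No measurement at hand offers an explanation for this result.

Going by these compounds alone, this single exchange covers only two substituted phenyl groups, so it cannot show whether this place tolerates other changes in general or simply responds little to this one. On these data alone, an amine or a carboxylic acid on the phenyl ring, or a longer chain in place of the ring, would bring in different kinds of group, and how such groups would affect the number in this assay remains open.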